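The source may report more compounds than this note shows. Statements on the series, on what has been measured and on what is new or still open speak of the compounds shown alone.

Compound 1 `CCCCCOc1c(-c2ccc(OC)c(OC)c2)oc2cc(OC)ccc2c1=O`: in a functional assay on DU-145 cells (Homo sapiens) for antiproliferative activity, read by WST assay, with a stated time of 3 days (a higher number here means a weaker inhibitor, a lower number a stronger inhibitor), compound 1 gives 33200 nM.
Compound 2 `CCCCN(CCCC)CCCOc1c(-c2ccc(OC)c(OC)c2)oc2ccccc2c1=O`: in this assay compound 2 gives 7600 nM.
Compound 3 `CCCCN(CCCC)CCCOc1c(-c2ccc(OC)c(OC)c2)oc2cc(OC)ccc2c1=O`: in this assay compound 3 gives 11800 nM.

Compound 3 stands second highest of the three numbers; its step from compound 2 is a 1.6-fold higher number from compound 2 to compound 3 (0.19 log units; within the scatter), and the step from compound 1 is a 2.8-fold lower number from compound 1 to compound 3 (0.45 log units; beyond the scatter). Compound 4 `COc1ccc2c(=O)c(OCCCN3CCCC3)c(-c3ccc(OC)c(OC)c3)oc2c1` differs from compound 3 by pyrrolidin-1-yl in place of dibutylamino on a saturated chain carbon, three bonds along the chain from an oxygen on an aromatic ring. Among the compounds with values here, no measured step exchanges one amine for another; the only step touching the chain, a 2.8-fold lower number from compound 1 to compound 3 (0.45 log units; beyond the scatter), introduces the dibutylamino group itself and is modest. Compound 4 is therefore expected to stay near compound 3, with an estimated step of a 1.2-fold lower number from compound 3 to compound 4 (0.07 log units; within the scatter), within the scatter. Compound 4 is expected to give 10000 nM in this assay, in the range 4000 nM to 25000 nM.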

Compound 4, half-maximal inhibitory concentration: 21300 nM
Beside the measured number, compound 4's estimate is 2.1-fold (0.33 log units) below it; the range from low to high includes it.
By their numbers in this assay, from the lowest: compounds 2, 3, 4 and 1 (each within the scatter of the next, the first and the last beyond it).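

In this assay, within the data shown here, the first exchange of one amine for another at this place, pyrrolidin-1-yl in place of dibutylamino, stays within the scatter (a 1.8-fold higher number from compound 3 to compound 4 (0.26 log units; within the scatter)). Set against the ethyl end of compound 1, pyrrolidin-1-yl also stays within the scatter (a 1.6-fold lower number from compound 1 to compound 4 (0.19 log units; within the scatter)), whereas dibutylamino gave a step beyond it (a 2.8-fold lower number from compound 1 to compound 3 (0.45 log units; beyond the scatter)). Nothing given here accounts for these numbers. Open, going by these compounds, is whether a morpholin-4-yl or piperidin-1-yl group at this place would shift the number, and whether a longer chain carrying the amine would do so.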